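Swapping the Alkenyl Arm for a Dihydroxypropyl Chain

The source may hold more compounds than are shown below. What is called first, only, known or untested is meant among the compounds shown, and "the series" means these compounds.

Measured compounds:
compound 1, `Nc1nc(O)c2c(n1)n(C1OC(CO)[C@@H](O)[C@H]1O)c(=O)n2C/C=C/c1ccccc1`, 73%
compound 2, `CCCn1c(=O)n(C2OC(COP(=O)(O)O)[C@@H](O)[C@H]2O)c2nc(N)nc(O)c21`, 76%
compound 3, `CC1OC(n2c(=O)n(C)c3c(O)nc(N)nc32)[C@H](O)[C@@H]1O`, 0%

In a functional assay on the whole organism (B cells) with Mus musculus as the target (on this read-out lower numbers stand for smaller maximal responses and higher numbers for larger maximal responses), compound 1 gives 73%. Among the three numbers this is the second highest. Its nearest neighbour is compound 2, whose value of 76% lies within the scatter of repeated measurements, so nothing separates the two. Its furthest neighbour is compound 3, which gives 0%, a gap that lies well beyond the scatter; compound 3 differs from compound 1 in more than one place, so no single change can be held responsible.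

The untested compound 4, `Nc1nc(O)c2c(n1)n(C1OC(CO)[C@@H](O)[C@H]1O)c(=O)n2CC(O)CO`, differs from compound 1 in one place: 1,2-dihydroxyethyl in place of 2-phenylethenyl on a saturated chain carbon bound to an aromatic nitrogen. Within the data shown here, no measured pair shows exactly this kind of change. Compound 2 shows that a short saturated chain at this position can hold a value of 76%, but it carries no hydroxyl groups on that chain. For compound 4 a moderate drop is expected, with the step of a number 13 percentage points lower from compound 1 to compound 4 (beyond the scatter) reaching a little beyond the scatter; the value is estimated at 60%, between 30% and 85%.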

Compound 4, largest response reached (reported as maximal response), in percent of the reference or control that the assay uses: 136%
The estimate for compound 4 lay 76 percentage points below the measured number; measured number above the stated range.
By their numbers in this assay, from the lowest: compound 3; then compounds 1 and 2 (each within the scatter of the next); then compound 4.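

In this assay, placing 1,2-dihydroxyethyl in place of 2-phenylethenyl on a saturated chain carbon bound to an aromatic nitrogen gives a number 63 percentage points higher from compound 1 to compound 4 (beyond the scatter), so the level of compound 1 is no ceiling for this position. The aromatic ring and the double bond outside it are not needed for a large maximal response, since compound 4 reaches 136% without either and with hydroxyl groups on the chain instead. Nothing available here explains why the step is so large.

Whether the rise follows the hydroxyl groups themselves or only the loss of 2-phenylethenyl stays open, as just one pair differing in this place is shown. The compounds also leave open how an amine, a carboxylic acid or a longer chain bearing hydroxyl groups would behave at this place.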